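Series notes: benzyl ether isoxazole piperazines, proliferation of liver cancer cells

A few compounds are considered here, and "the series" means these few. Any claim that something is new, unique, unknown or untested is made for them only; others in the source may bear on it.

Measured compounds:
compound 1 `Cc1ccccc1COc1ccc(-c2cc(CN3CCN(Cc4ccc(C(F)(F)F)cc4)CC3)no2)cc1` gives 6800 nM in a functional assay on Mahlavu cells (Homo sapiens) for antiproliferative activity, read by sulforhodamine B assay, with a stated time of 72 h; a lower number here means a stronger inhibitor, a higher number a weaker inhibitor
compound 2 `N#Cc1cccc(COc2ccc(-c3cc(CN4CCN(Cc5ccc(C(F)(F)F)cc5)CC4)no3)cc2)c1` gives 10600 nM in this assay
compound 3 `N#Cc1ccc(COc2ccc(-c3cc(CN4CCN(Cc5ccc(C(F)(F)F)cc5)CC4)no3)cc2)cc1` gives 4300 nM in this assay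

Three compounds share one core and differ only in the aryl group on the saturated chain carbon bound to the aromatic ring oxygen. Compound 2 has the highest number of the three: its nearest neighbour is compound 1 a 1.6-fold higher number from compound 1 to compound 2 (0.19 log units; within the scatter), a gap within the scatter, and its furthest is compound 3 a 2.5-fold lower number from compound 2 to compound 3 (0.39 log units; beyond the scatter), a modest gap beyond the scatter. The remaining comparison, a 1.6-fold lower number from compound 1 to compound 3 (0.20 log units; within the scatter), is also within the scatter.

Compound 4 `N#Cc1cccc(COc2ccc(-c3cc(CN4CCN(c5ccc(C(F)(F)F)cn5)CC4)no3)cc2)c1` keeps the 3-cyanophenyl ether of compound 2 and changes a different site: 5-(trifluoromethyl)pyridin-2-yl in place of 4-(trifluoromethyl)benzyl on an amine nitrogen in a ring. None of the three measured steps touches this amine nitrogen in a ring; all of them vary the ether aryl only, so nothing in hand speaks to the size or direction of this change in this assay. In the absence of a relevant step, compound 4 is expected to land near compound 2, with a broad range; the expected step is a 1.1-fold lower number from compound 2 to compound 4 (0.03 log units; within the scatter). The estimate for compound 4 is 10000 nM, expected between 3000 nM and 35000 nM.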

Compound 4, half-maximal inhibitory concentration: 1300 nM
Estimate against measurement, compound 4: 7.7-fold (0.89 log units) above, and the stated range ends above it.
By their numbers in this assay, from the lowest: compound 4; then compounds 3, 1 and 2 (each within the scatter of the next, the first and the last beyond it).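

The amine nitrogen in a ring is a site that moves the number in this assay: with the 3-cyanophenyl ether held fixed, 5-(trifluoromethyl)pyridin-2-yl in place of 4-(trifluoromethyl)benzyl gives an 8.2-fold lower number from compound 2 to compound 4 (0.91 log units; beyond the scatter), a larger step than the largest among the ether aryl changes, a 2.5-fold lower number from compound 2 to compound 3 (0.39 log units; beyond the scatter). This single step changes several features together: a group of 11 heavy atoms with a carbon-only aromatic ring gives way to one of 10 heavy atoms whose aromatic ring has 1 hetero atom and which carries 1 hydrogen-bond acceptor, so the step cannot be assigned to any one of these differences. No measurement shown here gives a reason for the step.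

Still open, on these data alone, is whether the same exchange on the amine nitrogen gives a step of similar size with the 2-methylphenyl or 4-cyanophenyl ether in place of the 3-cyanophenyl ether. Also open, as far as these compounds go, is how the ring hetero atom and the benzyl chain carbon each contribute, which a 5-(trifluoromethyl)pyridin-2-ylmethyl group or a 4-(trifluoromethyl)phenyl group on the same nitrogen would help to separate.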